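This account rests on a few compounds, and the source may have more. Where it says the series, first, only, none or still open, it means among the compounds named here.

Of the compounds shown here, two have so far been measured in an assay on cells for inhibition of MAP kinase-interacting serine/threonine-protein kinase 1 (Homo sapiens), read by mobility shift assay, with stated times of 10 min and 60 min, in the presence of a further agent that is not named here; a lower number here means a stronger inhibitor, a higher number a weaker inhibitor. Compound 1 `Cc1[nH]ncc1-c1cncc(-c2ccc(C(N)=O)c(OC(C)C)c2)c1` gives 54 nM in this assay, the lower of the two numbers recorded. Compound 2 `NC(=O)c1ccc(-c2ccc(N)nc2)cc1`, a much smaller molecule, gives 34000 nM in this assay, a gap from compound 1 that lies well beyond the usual scatter. Among the compounds with values here, the two share only part of their framework, so no single-site step between measured compounds can be counted, and the change now at issue has no measured precedent.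

Compound 3 `CC(C)Oc1cc(-c2cncc(-c3cnn(C)c3)c2)ccc1C(N)=O` has the same atoms as compound 1, joined differently: 1-methyl-1H-pyrazol-4-yl in place of 5-methyl-1H-pyrazol-4-yl on an aromatic carbon. With the exchange, the hydrogen-bond donor of the pyrazole in compound 1 is gone, while the ring itself and its methyl remain. Within the data shown here, no measured pair shows what this does on the shared core.

The expectation for compound 3 is a modest loss in potency, a step of a 2.8-fold higher number from compound 1 to compound 3 (0.44 log units; beyond the scatter) that may lie within or just beyond the scatter. Compound 3 is therefore expected to give about 150 nM in this assay, most likely between 40 nM and 600 nM.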

Compound 3, half-maximal inhibitory concentration: 400 nM
Compound 3: middle estimate off by 2.7-fold (0.43 log units), on the low side, within the range that was stated.
By their numbers in this assay, from the lowest: compound 1; then compound 3; then compound 2.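

In this assay, within the data shown here, the first single-site step on the shared core is a 7.4-fold higher number from compound 1 to compound 3 (0.87 log units; beyond the scatter), which shows that moving the methyl from 5-methyl-1H-pyrazol-4-yl to 1-methyl-1H-pyrazol-4-yl, on the same aromatic carbon and with the same atoms, changes the number beyond the scatter. The five-membered aromatic ring and its heavy atoms stay the same, while the group goes from 1 hydrogen-bond donor and 1 hydrogen-bond acceptor to 0 hydrogen-bond donors and 2 hydrogen-bond acceptors, and the step that goes with this exchange is a modest one. Nothing measured here bears on what sets the size of this step, so it cannot be tied to the lost donor, to the new place of the methyl or to anything else.

The compounds shown leave open whether the methyl or the hydrogen on the pyrazole nitrogen carries the difference, and a plain 1H-pyrazol-4-yl with no methyl would separate the two. Also open, from the compounds shown here alone, is how this position responds to a longer chain on the pyrazole nitrogen, such as ethyl, or to an amine in place of the pyrazole.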